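Trimming a Pyridin-2-yl Group from a Sulfonamide Nitrogen

The compounds below may be only part of what the source reports. "The series", "measured", "known", "first", "only" and "open" are said of these compounds alone.

Compound 1 `Clc1ccc(C(/C=C/c2ccccc2)=N\Nc2nncc3ccccc23)cc1`: 3.3 nM
Compound 2 `NC(=S)NNc1nncc2ccccc12`: 37 nM
Compound 3 `O=S(=O)(Nc1ccccn1)c1ccc(Nc2nncc3ccccc23)cc1`: 26 nM

Three compounds sharing one core were tested in a functional assay on HeLa cells (Homo sapiens) for antiproliferative activity, read by sulforhodamine B assay, with a stated time of 72 h; on this read-out lower numbers stand for stronger inhibition and higher numbers for weaker inhibition. Compound 3 gives the second highest of the three numbers, sitting within the usual scatter of compound 2 but well beyond it from compound 1, which has the lowest number of the set. Compound 4 `NS(=O)(=O)c1ccc(Nc2nncc3ccccc23)cc1` has not yet been tested in this assay; it differs from compound 3 in one place: hydrogen in place of pyridin-2-yl on a sulfonamide nitrogen. Within the data shown here, no measured pair shows the effect of such a removal, so expectation rests on compound 3 alone. A small step from compound 3 to compound 4, estimated as a 1.9-fold higher number from compound 3 to compound 4 (0.28 log units; within the scatter), is expected, most likely toward a somewhat higher number. Compound 4 is therefore estimated at 50 nM, with a plausible range from 15 nM to 200 nM.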

Compound 4, half-maximal inhibitory concentration: 12 nM
Estimate against measurement, compound 4: 4.2-fold (0.62 log units) above; measured number outside the range, below it.
By their numbers in this assay, from the lowest: compound 1; then compound 4; then compounds 3 and 2 (each within the scatter of the next).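

In this assay the sulfonamide nitrogen needs no pyridin-2-yl group: replacing it with hydrogen gives a 2.2-fold lower number from compound 3 to compound 4 (0.34 log units; beyond the scatter) and so removes six heavy atoms without any loss. Among these compounds, this modest gain is the first measured view of what this position tolerates, though it rests on a single pair. No measurement here explains why the number falls. As far as these compounds go, whether a methyl or acetyl group on that nitrogen would give a lower or higher number remains open. So does whether a phenyl ring would behave like pyridin-2-yl.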